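This account rests on a few compounds, and the source may have more. Where it says the series, first, only, none or still open, it means among the compounds named here.

Measured compounds:
Compound 1, `CC(=O)O[C@H]1C[C@H](C)[C@H]2C[C@H]2C2=C(COC2=O)[C@H]1[C@H](C)CCC=C(C)C`, gives > 10 ug/mL in a functional assay on P388 cells (Mus musculus) for cytotoxicity (a lower number here means that less compound is needed, a higher number that more compound is needed for the effect), a reading that is a limit of the assay and not a number.
Compound 2, `CC(=O)O[C@@H]1C(=O)C2C1CC/C=C(\C)CC[C@@H]2[C@H](C)CCC=C(C)C`, gives > 10 ug/mL in this assay, again a limit rather than a number.

Compound 2 therefore stands at the edge of what this assay can report: its reading is a limit, and the same is true of the only other value, as shown by the limit of > 10 ug/mL in this assay, at which 2 of the 2 values shown sit. Among the compounds with values here, no step between two measured compounds is available, so there is no measured guide to how a change of this kind moves the read-out.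

Compound 3, `CC(=O)O[C@H]1C(=O)C2C1CC/C=C(\C)CC[C@@H]2[C@H](C)CCC=C(C)C`, is the compound still to be tested. (the two compounds have the same atoms and bonds; at least one stereo element is drawn with a configuration in one of them and without one in the other: 1 of 6 stereo elements differ; a stereocentre at a saturated ring carbon is drawn S in compound 2 and R in compound 3). The atoms and bonds are the same, and the starting point is a limit, so the expected step from compound 2 to compound 3 in this assay is none beyond the usual scatter, a step that the limit leaves unreadable from compound 2 to compound 3. Compound 3 is thus expected to read about 15 ug/mL, somewhere between 5 ug/mL and 50 ug/mL, and most likely the assay will again return only a limit.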

Compound 3, concentration for half-maximal effect: > 10 ug/mL
Compound 3 was reported as a limit; the forecaster's own chance of this, stated with the estimate: 75%; the middle value lies beyond the limit too.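

No step can be read from compound 2 to compound 3, as the readings of both in this assay are limits and not numbers: the limit of > 10 ug/mL in this assay, at which 3 of the 3 values shown sit.

The compounds shown leave open whether the configuration at that saturated ring carbon affects the read-out at all, and how these compounds would compare if each gave a number.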